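This account rests on a few compounds, and the source may have more. Where it says the series, first, only, none or still open, it means among the compounds named here.

Working notes on the series, an ADME assay on MDBK cells (Bos taurus) for cytotoxicity; on this read-out higher numbers stand for lower toxicity in this test and lower numbers for higher toxicity in this test:

- compound 1 `Fc1cccc(F)c1Cn1c(-c2c(F)cccc2F)nc2cnccc21`: > 100000 nM, a limit
- compound 2 `Fc1cccc(F)c1-c1nc2ccn(Cc3ccccc3)cc-2n1`: > 100000 nM, a limit
- compound 3 `Cc1ccccc1Cn1ccc2nc(-c3ccccc3)nc-2c1`: > 100000 nM, a limit

Compound 3 reads > 100000 nM, which is a limit of the assay and not a number. It has no numeric neighbours in the series: the limit of > 100000 nM in this assay, at which 3 of the 3 values shown sit. Among the compounds with values here, no step between measured compounds is available, so the size of any structural effect cannot be read from these data.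

Compound 4 `COc1ccc(Cn2ccc3nc(-c4ccccc4)nc-3c2)cc1` carries 4-methoxyphenyl in place of 2-methylphenyl on a saturated chain carbon bound to an aromatic nitrogen.

The expected step in this assay, a number no higher from compound 3 to compound 4 (the limit leaves the size open), is none beyond the scatter, in neither direction. This expectation rests on compound 3 at > 100000 nM, a limit, and on the same limit being reached by the other two compounds. The assay will most likely report only a limit again. For compound 4 the estimate is 100000 nM, with an expected range of 40000 nM to 200000 nM.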

Compound 4, half-maximal cytotoxic concentration: > 100000 nM
Compound 4 gave a limit, no number (the forecaster's own chance of this, stated with the estimate: 85%); the middle value sits exactly at the limit.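

Compound 3 and compound 4 both return only a limit of the assay in this assay, so no step can be read between them: the limit of > 100000 nM in this assay, at which 4 of the 4 values shown sit.

The compounds shown leave open whether any structural change in the series shifts the result in this assay, and by how much.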